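Indolyl Hydrazone Replacing a Chlorophenyl on a Shared Core

The compounds below may be only part of what the source reports. "The series", "measured", "known", "first", "only" and "open" are said of these compounds alone.

Within the data shown here, in a functional assay on MGC-803 cells (Homo sapiens) for antiproliferative activity, read by MTT assay, with a stated time of 72 h (on this read-out higher numbers stand for weaker inhibition and lower numbers for stronger inhibition), compound 2 `CCCSc1nc(N/N=C/c2ccccc2Cl)c2nnn(Cc3ccccc3)c2n1` gives 10900 nM, the lowest of the two numbers measured so far, and its nearest neighbour is compound 1 `CCCSc1nc(N/N=C(\C)c2ccc(O)cc2)c2nnn(Cc3ccccc3)c2n1`, which in this assay gives 16700 nM. Among the measured compounds shown here, the one measured step, a 1.5-fold lower number from compound 1 to compound 2 (0.19 log units; within the scatter), lies within the scatter. Compound 3 `CCCSc1nc(N/N=C/c2c[nH]c3ccccc23)c2nnn(Cc3ccccc3)c2n1` has not yet been measured; it differs from compound 2 by 1H-indol-3-yl in place of 2-chlorophenyl on a carbon with a double bond to nitrogen. For the measured compounds named here, no measured step swaps a 2-chlorophenyl for a 1H-indol-3-yl, so the only guide is that the single change seen on this carbon, from compound 1 to compound 2, did not move the number beyond the scatter. A step beyond the scatter is therefore not expected in this assay, and compound 3 is expected to give 9000 nM, with a range from 3000 nM to 30000 nM. The expected step of a 1.2-fold lower number from compound 2 to compound 3 (0.08 log units; within the scatter) is thus estimated to stay within the scatter.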

Compound 3, half-maximal inhibitory concentration: 7410 nM
Beside the measured number, compound 3's estimate is 1.2-fold (0.08 log units) above it; the measured number falls inside the stated range.
By their numbers in this assay, from the lowest: compounds 3, 2 and 1 (each within the scatter of the next, the first and the last beyond it).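

In this assay the change gives a 1.5-fold lower number from compound 2 to compound 3 (0.17 log units; within the scatter), so on this carbon 1H-indol-3-yl, with its five-membered aromatic ring and a hydrogen-bond donor, takes the place of 2-chlorophenyl without a step beyond the scatter. Among these compounds, both steps read at this place so far stay within the scatter, yet compound 3 and compound 1, the two ends of the order, lie beyond the scatter of each other. Nothing measured here bears on what lies behind these numbers.

From the compounds shown here alone, whether an amine or a carboxylic acid on this carbon, in place of the aromatic ring, would move the number beyond the scatter remains open. The compounds shown also leave open how a longer chain on the sulfur of the shared core would read.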